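Branching the Side Chain of an Anilino Oxindole

A few compounds are considered here, and "the series" means these few. Any claim that something is new, unique, unknown or untested is made for them only; others in the source may bear on it.

Compound 1 `CCCCCC1(O)C(=O)Nc2ccc(Nc3ccc(C)cc3)cc21` returns only a limit in a functional assay on NCI-H460 cells (Homo sapiens) for antiproliferative activity, read by MTT assay, with a stated time of 48 h (a lower number here means a stronger inhibitor, a higher number a weaker inhibitor), namely > 100000 nM (the limit of > 100000 nM in this assay, at which 1 of the 3 values shown sits). Compound 2 `Cc1ccc(Nc2ccc3c(c2)C(O)(CCC(C)C)C(=O)N3)cc1` differs from compound 1 by isopropyl in place of propyl on a saturated chain carbon, two bonds along the chain from a saturated ring carbon; in this assay compound 2 gives 22700 nM, a step of an at least 4.4-fold lower number from compound 1 to compound 2 (0.64 log units; beyond the scatter). Compound 3 `CCCCCC1(O)C(=O)Nc2ccc(Nc3ccc(C(F)(F)F)cc3)cc21` differs from compound 1 by trifluoromethyl in place of methyl on an aromatic carbon; in this assay compound 3 gives 16300 nM, a step of an at least 6.1-fold lower number from compound 1 to compound 3 (0.78 log units; beyond the scatter). The values of compound 2 and compound 3 lie within the scatter of each other. Compound 4 `CC(C)CCC1(O)C(=O)Nc2ccc(Nc3ccc(C(F)(F)F)cc3)cc21` has not been measured; it differs from compound 3 by isopropyl in place of propyl on a saturated chain carbon, two bonds along the chain from a saturated ring carbon, the same change already made from compound 1 to compound 2. A smaller gain of the same kind is expected, because an at least 4.4-fold lower number from compound 1 to compound 2 (0.64 log units; beyond the scatter) is seen only once and starts from a limit. Compound 4 is therefore estimated at 6500 nM in this assay, between 2000 nM and 17000 nM. This corresponds to an expected step of a 2.5-fold lower number from compound 3 to compound 4 (0.40 log units; beyond the scatter).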

Compound 4, half-maximal inhibitory concentration: 17200 nM
The estimate for compound 4 lay 2.6-fold (0.42 log units) below the measured number, and the stated range ends below it.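

On the core of compound 3, the change from propyl to isopropyl does not repeat what it did on the core of compound 1 in this assay, with a 1.1-fold higher number from compound 3 to compound 4 (0.02 log units; within the scatter) and the two steps clearly apart: the same change on two cores in this assay, an at least 4.4-fold lower number (0.64 log units; beyond the scatter) from compound 1 to compound 2 and a 1.1-fold higher number (0.02 log units; within the scatter) from compound 3 to compound 4, at least 4.6-fold (0.66 log units) apart, beyond the scatter of two such steps. Trifluoromethyl in place of methyl likewise gives no step beyond the scatter once the isopropyl chain end is present, with a 1.3-fold lower number from compound 2 to compound 4 (0.12 log units; within the scatter): the same change on two cores in this assay, an at least 6.1-fold lower number (0.78 log units; beyond the scatter) from compound 1 to compound 3 and a 1.3-fold lower number (0.12 log units; within the scatter) from compound 2 to compound 4, at least 4.6-fold (0.66 log units) apart, beyond the scatter of two such steps. Compound 1 gives only a limit, > 100000 nM, which leaves the full gap unfixed, and these four compounds neither explain the mismatch nor set a rule for other cores.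

On these data alone, whether a longer chain on the saturated ring carbon would move the number remains open. So does the effect of an amine or a carboxylic acid at the chain end.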